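Bromo to cyano on the amide-bound ring

The source may report more compounds than this note shows. Statements on the series, on what has been measured and on what is new or still open speak of the compounds shown alone.

Of the compounds shown here, three sharing one core have been measured in a functional assay on A549 cells (Homo sapiens) for inhibition, read by CCK-8 assay, with a stated time of 72 h, tested at 10 uM; a higher number here means more inhibition of growth at the concentration tested, a lower number less inhibition of growth. Compound 1 `CN(C)C(=O)c1cc2cnc(Nc3ccc(NC(=O)C4(C(=O)Nc5ccccc5F)CC4)cc3)nc2n1C1CCCC1` gives 88.6%. Compound 2 `CN(C)C(=O)c1cc2cnc(Nc3ccc(NC(=O)C4(C(=O)Nc5ccc(Br)cc5)CC4)cc3)nc2n1C1CCCC1` gives 90.3%, which is the second highest of the three numbers; its nearest neighbour is compound 1, with the step of a number 1.7 percentage points higher from compound 1 to compound 2 (within the scatter), and its furthest is compound 3, with the step of a number 4.1 percentage points higher from compound 2 to compound 3 (within the scatter). Compound 3 `CN(C)C(=O)c1cc2cnc(Nc3ccc(NC(=O)C4(C(=O)Nc5ccc(O)cc5)CC4)cc3)nc2n1C1CCCC1` gives 94.4%, and the step of a number 5.8 percentage points higher from compound 1 to compound 3 (within the scatter) is likewise small.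

Compound 4 `CN(C)C(=O)c1cc2cnc(Nc3ccc(NC(=O)C4(C(=O)Nc5ccc(C#N)cc5)CC4)cc3)nc2n1C1CCCC1` has not yet been measured. It differs from compound 2 in one place: cyano in place of bromo on an aromatic carbon. Among the measured compounds shown here, two measured steps bear on this change. The step of a number 4.1 percentage points higher from compound 2 to compound 3 (within the scatter) exchanges the same bromo on the same aromatic carbon for hydroxy and stays within the scatter, and the step of a number 1.7 percentage points higher from compound 1 to compound 2 (within the scatter) exchanges the whole aromatic ring attached to the amide-type nitrogen and also stays within the scatter. Every change tried at this part of the molecule has left the growth inhibition essentially unchanged, so no step beyond the scatter is expected, and a number 0.3 percentage points lower from compound 2 to compound 4 (within the scatter) is the estimated movement. For compound 4 the estimated value is 90%, expected to lie between 82% and 96%.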

Compound 4, percent growth inhibition at one concentration: 95%
Compound 4: the middle estimate sits 5 percentage points below what was measured, and the stated range covers the measured number.
By their numbers in this assay, from the lowest: compounds 1, 2, 3 and 4 (each within the scatter of the next).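

Cyano is a third group at this position, on an aromatic carbon para to a large group, and in this assay it also stays within the scatter when it replaces bromo (a number 4.7 percentage points higher from compound 2 to compound 4 (within the scatter)) or hydroxy (a number 0.6 percentage points higher from compound 3 to compound 4 (within the scatter)). Exchanging the whole ring, with 4-cyanophenyl in place of 2-fluorophenyl, likewise stays within the scatter (a number 6.4 percentage points higher from compound 1 to compound 4 (within the scatter)), so in these four compounds, bromo, hydroxy and cyano on the 4-substituted ring and a fluorine-bearing ring give numbers that cannot be told apart in this read-out. Nothing available explains why these exchanges leave the number within the scatter.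

The compounds shown leave open whether an amine, a carboxylic acid or a longer chain such as a butoxy group at this position would move the growth inhibition beyond the scatter, or whether this end of the molecule can tolerate nearly any group. They also leave open whether these four compounds would separate at lower concentrations, since a reading at a single concentration gives no full dose-response comparison.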